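The source may report more compounds than this note shows. Statements on the series, on what has been measured and on what is new or still open speak of the compounds shown alone.

Compound 1 `COc1cc(OC)cc(C(=CC(N)=O)c2ccc(OC)c(OC)c2)c1` | > 10000 nM
Compound 2 `COC=C(c1cc(OC)cc(OC)c1)c1ccc(OC)c(OC)c1` | > 10000 nM

Both compounds were tested in a functional assay on HCT-116 cells (Homo sapiens) for cytotoxicity, read by scintillation counting and thymidine incorporation, with a stated time of 72 h; on this read-out lower numbers stand for stronger inhibition and higher numbers for weaker inhibition. Compound 2 stands at > 10000 nM, which is a limit and not a number. Compound 1 gives > 10000 nM, also a limit. The evidence so far is the limit of > 10000 nM in this assay, at which 2 of the 2 values shown sit, so compound 2 has no numeric position in the series.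

Compound 3 `COC(=O)C=C(c1cc(OC)cc(OC)c1)c1ccc(OC)c(OC)c1` carries methoxycarbonyl in place of methoxy on a double-bonded chain carbon bound to a double-bonded chain carbon, with the count of the change being (methoxycarbonyl in place of methoxy on a double-bonded chain carbon bound to a double-bonded chain carbon). For the measured compounds named here, the one measured step at this place is a step that the two limits leave unreadable from compound 1 to compound 2, and it supplies no size to carry over. On these data alone, no readable gain is therefore expected in this assay, and the expected direction stays open. The estimated step that the limit leaves unreadable from compound 2 to compound 3 is only a rough figure. For compound 3 the expected value is 15000 nM, with an estimated range from 5000 nM to 40000 nM.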

Compound 3, half-maximal inhibitory concentration: > 10000 nM
Compound 3: no number, only a limit; the forecaster's own chance of this, stated with the estimate: 85%; the middle value is on the limit's open side.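

No step can be read among compound 1, compound 2 and compound 3 in this assay, since each value is a limit and not a number: the limit of > 10000 nM in this assay, at which 3 of the 3 values shown sit. The compounds shown leave open how far any of the three lies beyond that limit, and whether these changes shift activity at all.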